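Changing the group on the ring nitrogen: compound 4

The compounds below may be only part of what the source reports. "The series", "measured", "known", "first", "only" and "open" are said of these compounds alone.

Of the compounds shown here, three with a shared core have been measured so far. Compound 1 `Oc1cc(C(F)(F)F)ccc1-c1nc(-c2ccccc2O)n(-c2ccc(Cl)cc2)n1` gives 96.1% in a functional assay on PC-12 cells (Rattus norvegicus) for cytotoxicity, read by MTT assay, with stated times of 2 h and 24 h, tested at 10 uM; on this read-out higher numbers stand for a stronger effect at the one concentration tested and lower numbers for a weaker effect. Compound 2 `Oc1cc(C(F)(F)F)ccc1-c1nc(-c2ccccc2O)n(-c2ccc(OC(F)(F)F)cc2)n1` gives 92.5%, and compound 3 `Oc1cc(C(F)(F)F)ccc1-c1nc(-c2ccccc2O)n(-c2cccc(C(F)(F)F)c2)n1` gives 99.9%. Among these three numbers compound 2 holds the lowest, yet the gaps are small: the step of a number 3.6 percentage points lower from compound 1 to compound 2 (within the scatter) and the step of a number 7.4 percentage points higher from compound 2 to compound 3 (within the scatter) both fall inside the usual scatter, so the three compounds cannot be told apart on this read-out.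

Compound 4 `Cc1cc(C)cc(-n2nc(-c3ccc(C(F)(F)F)cc3O)nc2-c2ccccc2O)c1` has not been measured yet. Relative to compound 2, the change is 3,5-dimethylphenyl in place of 4-(trifluoromethoxy)phenyl on an aromatic nitrogen. Going by the values given here, the steps that bear on this change are those in which the group on the same aromatic nitrogen was exchanged: a number 3.8 percentage points higher from compound 1 to compound 3 (within the scatter) and a number 7.4 percentage points higher from compound 2 to compound 3 (within the scatter), both within the scatter. Among the compounds with values here, no measured compound carries a 3,5-dimethylphenyl group, so nothing directly tests this substituent.

Given that every exchange at this position so far left the number essentially unchanged, compound 4 is expected to stay in the same high range, and the expected step is a number 2.5 percentage points higher from compound 2 to compound 4 (within the scatter). The estimate for compound 4 is 95%, with a range from 84% to 100%.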

Compound 4, a percentage reported as activity, at one concentration (the size of the read-out at that concentration, not a potency): 105%
Beside the measured number, compound 4's estimate is 10 percentage points below it; measured number above the stated range.
By their numbers in this assay, from the lowest: compounds 2, 1, 3 and 4 (each within the scatter of the next, the first and the last beyond it).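

Going by these compounds alone, at this aromatic nitrogen, placing 3,5-dimethylphenyl in place of 4-(trifluoromethoxy)phenyl is the first exchange in this assay to clear the usual scatter, with a number 12.5 percentage points higher from compound 2 to compound 4 (beyond the scatter), so the position is not wholly indifferent to its group. Within the data shown here, the separation holds against only one neighbour, however: the same group gives a number 5.1 percentage points higher from compound 3 to compound 4 (within the scatter) and a number 8.9 percentage points higher from compound 1 to compound 4 (within the scatter), so compound 4 stands apart from compound 2 alone, while compound 1 and compound 3 cannot be told apart from it. The 3,5-dimethylphenyl group is also the only one shown at this position that is built of carbon alone, yet no measurement here ties the step to that feature or to anything else.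

From the compounds shown here alone, whether both methyl groups are needed remains open, since a phenyl ring with a single methyl would be the direct test. Going by these compounds, it is equally open what a phenyl ring carrying an amine or a carboxylic acid, or a simple alkyl chain in place of the ring, would do at this nitrogen.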